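This account rests on a few compounds, and the source may have more. Where it says the series, first, only, none or still open, it means among the compounds named here.

Of the compounds shown here, two sharing one core have been measured in an assay on HEK293 cells for agonist activity at transient receptor potential cation channel subfamily M member 8 (Homo sapiens), read by fluorescence and calcium flux, with a stated time of 15 min; on this read-out lower numbers stand for an effect already at smaller amounts and higher numbers for an effect only at larger amounts of compound. Compound 1 `CCN(Cc1cccs1)C(=O)COc1ccccc1` gives 1400 nM in this assay, while compound 2 `CCN(Cc1cccs1)C(=O)COc1cc(C)ccc1O` gives 24 nM. Compound 2 thus stands at the lower of the two numbers, and the gap to compound 1 lies well beyond the usual scatter. Compound 3 `CCN(Cc1cccs1)C(=O)COc1cccc(C)c1` is not yet measured; it differs from compound 2 in one place: hydrogen in place of hydroxy on an aromatic carbon. Among the compounds with values here, no step between measured compounds isolates this change: compound 1 lacks both the hydroxy and the methyl group carried by compound 2, so how much of the gap between compound 1 and compound 2 belongs to the hydroxy cannot be read from the numbers. A step towards higher numbers is expected, of the size a 13-fold higher number from compound 2 to compound 3 (1.10 log units; beyond the scatter), beyond the scatter. For compound 3 the expected value in this assay is 300 nM, within a range of 60 nM to 1500 nM.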

Compound 3, half-maximal effective concentration: 97 nM
For compound 3 the middle estimate is 3.1-fold (0.49 log units) above the measured one; measured number inside the range.
By their numbers in this assay, from the lowest: compound 2; then compound 3; then compound 1.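

In this assay, within the data shown here, the gap left unresolved by the earlier compounds can now be divided, since each group has its own single-change step. The methyl group alone, without the hydroxy, accounts for the large step, a 14-fold lower number from compound 1 to compound 3 (1.16 log units; beyond the scatter), so much of the gain needs no hydroxy at all. The hydroxy on the aromatic carbon ortho to a large group still counts, though more modestly: replacing it with hydrogen gives a 4.0-fold higher number from compound 2 to compound 3 (0.61 log units; beyond the scatter), and no evidence at hand explains either step.

The compounds shown leave open whether the hydroxy would give a step of the same size without the methyl group. They also leave open whether a methoxy group or an amine on that same carbon would hold the number as low as the hydroxy does.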